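A few compounds are considered here, and "the series" means these few. Any claim that something is new, unique, unknown or untested is made for them only; others in the source may bear on it.

Measured in a functional assay on PC-3 cells (Homo sapiens) for inhibition, with a stated time of 48 h, tested at 50 uM (on this read-out lower numbers stand for less inhibition of growth and higher numbers for more inhibition of growth at the one concentration tested), so far:
Compound 1 `CC[C@](C)(CCCC(C)C)CCc1ccc(O)c(I)c1` gives 8%
Compound 2 `COc1ccc(/C=C/[C@@](C)(/C=C/c2ccc(O)cc2)CCC=C(C)C)cc1` gives 50%
Compound 3 `CC(C)=CCCC(C)(/C=C/c1ccc(O)cc1)/C=C/c1ccc(O)cc1` gives 32%

Of these three, compound 3 holds the middle place, with compound 2 higher and compound 1 lower, both gaps lying beyond the scatter. The next compound to be tested is compound 4 `COc1ccc(/C=C/[C@](C)(/C=C/c2ccc(O)cc2)CCC=C(C)C)cc1` and it differs from compound 3 in one place: methyl in place of hydrogen on an oxygen on an aromatic ring in a single change, methyl in place of hydrogen on an oxygen on an aromatic ring. Within the data shown here, one measured step bears on this, since it shows the same exchange in the opposite direction: a number 18 percentage points lower from compound 2 to compound 3 (beyond the scatter) in a modest change beyond the scatter. Among the measured compounds shown here, compound 1 offers no matching step. For the measured compounds named here, with only this one precedent, a rise of similar modest size is expected in this assay, though its size remains uncertain. The expected change is a number 15 percentage points higher from compound 3 to compound 4 (beyond the scatter) on this estimate. For compound 4 the estimated value is 47% in the middle, with an expected range from 32% to 62% as the likely span.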

Compound 4, percent growth inhibition at one concentration: 93%
Beside the measured number, compound 4's estimate is 46 percentage points below it; measured number above the stated range.
By their numbers in this assay, from the lowest: compound 1; then compound 3; then compound 2; then compound 4.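

In this assay the methyl on an oxygen on an aromatic ring has no single worth, for the exchange that gave only a modest difference in one configuration gives a far larger one in the other: a number 61 percentage points higher from compound 3 to compound 4 (beyond the scatter), while a number 18 percentage points lower from compound 2 to compound 3 (beyond the scatter). The stereocentre at a saturated chain carbon also matters in its own right, as a number 43 percentage points higher from compound 2 to compound 4 (beyond the scatter), and this centre is drawn R in the lower compound and S in the higher. This gap can be set down to one feature alone: the fact that compounds 2 and 4 differ only in the configuration as drawn

Still open, on these data alone, is whether an ethyl or an acetyl group on that oxygen would hold the number seen for compound 4. Also open, as far as these compounds go, is what a methyl on both aromatic oxygens would do in either configuration.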